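Pyridyl for phenyl on the sulfur-linked ethyl arm

The source may hold more compounds than are shown below. What is called first, only, known or untested is meant among the compounds shown, and "the series" means these compounds.

Measured compounds:
Compound 1 `CC(Sc1nc2nn(CC3COC3)cc2c(=O)n1-c1ccccc1)c1ccccc1` — 80 nM
Compound 2 `C[C@@H](Sc1nc2c(cnn2C)c(=O)n1-c1ccccc1)c1ccccc1` — 40 nM

In an assay on isolated protein for inhibition of retinal dehydrogenase 2 (Homo sapiens) (on this read-out lower numbers stand for stronger inhibition and higher numbers for weaker inhibition), compound 2 gives 40 nM, the lowest of the two numbers, while compound 1 gives 80 nM; the two values lie within the scatter of each other, so no order between them can be claimed. Compound 3 `CC(Sc1nc2c(cnn2C)c(=O)n1-c1ccccc1)c1cccnc1` has not yet been measured. It differs from compound 2 in one place: 1-(pyridin-3-yl)ethyl in place of 1-phenylethyl on a sulfur. Among the measured compounds shown here, no measured pair shows this kind of change, so its size is uncertain; a modest weakening, a 1.8-fold higher number from compound 2 to compound 3 (0.24 log units; within the scatter), is expected. Compound 3 is estimated at 70 nM, in the range 25 nM to 200 nM.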

Compound 3, half-maximal inhibitory concentration: 89 nM
Compound 3: the middle estimate sits 1.3-fold (0.10 log units) below what was measured; low and high end bracket the measured number.
By their numbers in this assay, from the lowest: compounds 2, 1 and 3 (each within the scatter of the next, the first and the last beyond it).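

In this assay, among the compounds shown here, putting 1-(pyridin-3-yl)ethyl in place of 1-phenylethyl on the sulfur gives a 2.2-fold higher number from compound 2 to compound 3 (0.35 log units; beyond the scatter) and is the first single-place step here, showing that this arm keeps activity with a ring nitrogen at a modest cost. The entering group adds a hydrogen-bond acceptor and, unlike the leaving group, has no defined stereocentre, so the step does not separate these two differences. No evidence at hand accounts for the step.

The compounds shown leave open how a 1-(pyridin-4-yl)ethyl or 1-(4-fluorophenyl)ethyl group would behave on this sulfur. They also leave open how the separate mirror forms of compound 3 compare.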